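Bromo substitution on the aryl amine of compound 2

The source may report more compounds than this note shows. Statements on the series, on what has been measured and on what is new or still open speak of the compounds shown alone.

Measured so far:
Compound 1 `Clc1ccc2oc(Nc3ccccc3)nc2c1`: 4500 nM
Compound 2 `COc1ccc2oc(Nc3ccccc3)nc2c1`: 7880 nM
Compound 3 `COc1ccc2oc(Nc3ccc(SC)cc3)nc2c1`: 2770 nM

In an assay on isolated protein (strain Balb/c) for inhibition of Polyunsaturated fatty acid 5-lipoxygenase (Mus musculus), read by immunoassay, with a stated time of 20 min (on this read-out lower numbers stand for stronger inhibition and higher numbers for weaker inhibition), compound 2 stands at the highest of the three numbers. Compound 1 lies nearest, within the scatter of compound 2, so no order between those two is claimed; compound 3 lies furthest, beyond the scatter.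

Compound 4 `COc1ccc2oc(Nc3cccc(Br)c3)nc2c1` differs from compound 2 by bromo in place of hydrogen on an aromatic carbon. Of the measured steps, a 2.8-fold lower number from compound 2 to compound 3 (0.45 log units; beyond the scatter) is the one that bears on it, since it also adds a group on the six-membered aromatic ring of carbon only and gave a modest lowering. The step of a 1.8-fold higher number from compound 1 to compound 2 (0.24 log units; within the scatter) concerns the shared core, not the ring changed here, and is within the scatter, so it says little about compound 4. One relevant step is thin ground, and bromo is not methylsulfanyl, so the expectation is held loosely.

Because a 2.8-fold lower number from compound 2 to compound 3 (0.45 log units; beyond the scatter) showed that an added group on this ring can lower the number, a modest lowering is expected for compound 4, a 2.0-fold lower number from compound 2 to compound 4 (0.29 log units; within the scatter). The estimate for compound 4 in this assay is 4000 nM, with a range from 1500 nM to 10000 nM.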

Compound 4, half-maximal inhibitory concentration: 2030 nM
Compound 4: middle estimate off by 2.0-fold (0.29 log units), on the high side, and the stated range covers the measured number.
By their numbers in this assay, from the lowest: compounds 4, 3, 1 and 2 (each within the scatter of the next, the first and the last beyond it).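

In this assay, bromo in place of hydrogen on an aromatic carbon gives a 3.9-fold lower number from compound 2 to compound 4 (0.59 log units; beyond the scatter), so this single bromine atom, meta to a large group on the six-membered aromatic ring of carbon only, is enough to move the number beyond the scatter. Within the data shown here, until now the only step on this ring beyond the scatter was the methylsulfanyl one, a 2.8-fold lower number from compound 2 to compound 3 (0.45 log units; beyond the scatter), and the series now holds two different groups that each lower the number relative to compound 2, though compound 3 and compound 4 differ in more than one place and are not set against each other here. No measurement shown accounts for the lowering seen with bromo.

As far as these compounds go, it remains open whether bromo gives a similar step on the core of compound 1, where chloro stands in place of methoxy, or at another carbon of the same ring. An amine, a carboxylic acid or a longer chain such as butyl at the place now held by bromo would show whether the lowering extends beyond bromo and methylsulfanyl.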